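Compound 3 to compound 4: fluoro in place of methoxy

The source may hold more compounds than are shown below. What is called first, only, known or untested is meant among the compounds shown, and "the series" means these compounds.

Measured in an ADME assay on THP-1 cells (Homo sapiens) for cytotoxicity, read by flow cytometry and propidium iodide staining, with a stated time of 72 h; a lower number here means a stronger inhibitor, a higher number a weaker inhibitor:
- Compound 1 `CC(=O)Nc1ccc2oc(-c3ccccc3F)cc(=O)c2c1`: > 125000 nM (a limit of the assay, not a number)
- Compound 2 `COc1ccccc1-c1oc2ccc(NC(C)=O)cc2c(=O)c1O`: > 125000 nM (a limit of the assay, not a number)
- Compound 3 `COc1ccccc1-c1oc2ccc(NC(C)=O)cc2c(=O)c1OC`: 108000 nM

In this assay, within the data shown here, compound 3 gives 108000 nM, the only true number among the three. The other two results are limits, described by the limit of > 125000 nM in this assay, at which 2 of the 3 values shown sit.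

The next compound is compound 4 `COc1c(-c2ccccc2F)oc2ccc(NC(C)=O)cc2c1=O`. It differs from compound 3 as follows: fluoro in place of methoxy on an aromatic carbon. In words, 2-methoxyphenyl becomes 2-fluorophenyl.

Among the measured compounds shown here, only one measured step is available: an at least 1.1-fold lower number from compound 2 to compound 3 (0.06 log units; that floor lies within the scatter). It concerns a different change, methyl in place of hydrogen on an oxygen, and its floor lies within the scatter. For the measured compounds named here, no measured step shows this swap directly. Compound 1 also carries 2-fluorophenyl, and its result of > 125000 nM is a limit.

On this evidence, no step beyond the scatter is expected in this assay, and another limit would be no surprise. The expected change is a 1.1-fold higher number from compound 3 to compound 4 (0.05 log units; within the scatter), an estimate within the scatter. For compound 4 the estimated value is 120000 nM, with an expected range from 70000 nM to 200000 nM.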

Compound 4, half-maximal inhibitory concentration: > 125000 nM
Compound 4 ended at the assay's limit (the forecaster's own chance of this, stated with the estimate: 55%); middle value at least 1.0-fold (0.01 log units) away from the limit.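

In this assay compound 4 gives > 125000 nM, which is a limit of the assay and not a number. Replacing 2-methoxyphenyl with 2-fluorophenyl gives an at least 1.1-fold higher number from compound 3 to compound 4 (0.06 log units; that floor lies within the scatter), so this swap on the aromatic carbon shows no change beyond the scatter, although a limit cannot exclude a larger one. Compound 1 and compound 4 both sit at the limit, so the step between them, which places methoxy where compound 1 has hydrogen, cannot be read, and any effect of that added methoxy stays hidden: the limit of > 125000 nM in this assay, at which 3 of the 4 values shown sit.

On these data alone, it remains open whether a different group on this aromatic carbon, such as an amine or a carboxylic acid, would bring the result clearly under the limit. As far as these compounds go, since compound 3 alone has a true number, 108000 nM, the real size of any effect from changing this group in this assay also remains unknown.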